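A Bromo Step Repeated on a Second Core

This account rests on a few compounds, and the source may have more. Where it says the series, first, only, none or still open, it means among the compounds named here.

Compound 1 `COc1ccc(C2CC(c3ccccc3)=NN2C2=NC(=O)/C(=C3\C(=O)Nc4ccccc43)S2)cc1` and compound 2 `COc1ccc(C2CC(c3ccccc3)=NN2C2=NC(=O)/C(=C3\C(=O)Nc4ccc(Br)cc43)S2)cc1` share one core and differ by bromo in place of hydrogen on an aromatic carbon. In a functional assay on cells (Leukemia cell, Homo sapiens) for cytotoxicity, read by sulforhodamine B assay, with a stated time of 48 h (a lower number here means a stronger inhibitor of growth, a higher number a weaker inhibitor of growth), compound 1 gives 20800 nM, and compound 2 gives 4230 nM, so the change brings a 4.9-fold lower number from compound 1 to compound 2 (0.69 log units; beyond the scatter). Compound 3 `COc1ccc(C2=NN(C3=NC(=O)/C(=C4\C(=O)Nc5ccccc54)S3)C(c3ccc(Cl)cc3)C2)cc1` carries a different core; the difference between the two cores is not broken down here. In this assay compound 3 gives 90900 nM, the highest of the three numbers. Compound 4 `COc1ccc(C2=NN(C3=NC(=O)/C(=C4\C(=O)Nc5ccc(Br)cc54)S3)C(c3ccc(Cl)cc3)C2)cc1` is not yet measured and differs from compound 3 by bromo in place of hydrogen on an aromatic carbon, the same change that separates compound 1 from compound 2. For compound 4 a step of similar size is expected, a 4.5-fold lower number from compound 3 to compound 4 (0.66 log units; beyond the scatter), because the earlier change gave a 4.9-fold lower number from compound 1 to compound 2 (0.69 log units; beyond the scatter). Compound 4 is therefore estimated at 20000 nM in this assay, with a range from 8000 nM to 50000 nM.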

Compound 4, concentration for total growth inhibition: 14000 nM
For compound 4 the middle estimate is 1.4-fold (0.15 log units) above the measured one; the range from low to high includes it.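

In this assay, bromo in place of hydrogen on an aromatic carbon brings a 6.5-fold lower number from compound 3 to compound 4 (0.81 log units; beyond the scatter), so the change carries over to the second core with a step of much the same size as on the first: the same change on two cores in this assay, a 4.9-fold lower number (0.69 log units; beyond the scatter) from compound 1 to compound 2 and a 6.5-fold lower number (0.81 log units; beyond the scatter) from compound 3 to compound 4, 1.3-fold (0.12 log units) apart, within the scatter of two such steps. This holds for these two cores and this one assay only. It does not show how the change would behave on any further core, and it does not explain the difference between the two cores.

Going by these compounds, it remains open whether fluoro, an amine or a carboxylic acid in place of the bromo would give a step of similar size. On these data alone, it also remains open whether bromo on another carbon of that ring would do so.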